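The compounds below may be only part of what the source reports. "The series", "measured", "known", "first", "only" and "open" are said of these compounds alone.

Compound 3 `CCn1cc(C(=O)O)c(=O)c2cc(F)c(N3CCN(C(=N)NS(=O)(=O)c4ccccc4)CC3)cc21` carries a phenylsulfonyl group. In a functional assay on A549 cells (Homo sapiens) for antiproliferative activity, read by MTT assay, with a stated time of 72 h (a lower number here means a stronger inhibitor, a higher number a weaker inhibitor), compound 3 gives 71 nM, level with compound 1 `CCn1cc(C(=O)O)c(=O)c2cc(F)c(N3CCN(C(=N)NS(=O)(=O)c4ccc(C(F)(F)F)cc4)CC3)cc21`, which gives 71 nM, and with compound 2 `CCn1cc(C(=O)O)c(=O)c2cc(F)c(N3CCN(C(=N)NS(=O)(=O)c4cccc(Cl)c4)CC3)cc21`, which gives 71 nM. Compound 4 `CCn1cc(C(=O)O)c(=O)c2cc(F)c(N3CCN(C(=N)NS(=O)(=O)c4ccc(C)cc4)CC3)cc21` differs from compound 3 in one place: methyl in place of hydrogen on an aromatic carbon. Going by the values given here, three measured steps bear on this, all of them changes on the same aromatic ring: no change at the digits printed from compound 1 to compound 3 (within the scatter), no change at the digits printed from compound 2 to compound 3 (within the scatter) and no change at the digits printed from compound 1 to compound 2 (within the scatter). Since none of these moved beyond the scatter, the step is expected to show no change at the digits printed from compound 3 to compound 4 (within the scatter), with no direction favoured. Compound 4 is therefore estimated to give 71 nM, within a range from 35 nM to 140 nM.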

Compound 4, half-maximal inhibitory concentration: 71 nM
Beside the measured number, compound 4's estimate shows no gap at the digits printed; measured number inside the range.
By their numbers in this assay, from the lowest: compounds 1, 2, 3 and 4 (each within the scatter of the next).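

Methyl is the first carbon group of its kind on this ring, and in this assay it gives no change at the digits printed from compound 3 to compound 4 (within the scatter). The other two comparisons read the same: no change at the digits printed from compound 2 to compound 4 (within the scatter) and no change at the digits printed from compound 1 to compound 4 (within the scatter), so methyl and trifluoromethyl, each para to a large group, cannot be told apart here. No measurement shown offers an explanation for this flat reading. The compounds shown leave open whether an amine, a carboxylic acid or a longer chain at this place would keep the value level, and whether a change on the shared core would move it.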